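A few compounds are considered here, and "the series" means these few. Any claim that something is new, unique, unknown or untested is made for them only; others in the source may bear on it.

Within the data shown here, compound 2 `O=C(Nc1cc(-c2ccccc2)nn1-c1ccccc1)c1ccc([N+](=O)[O-])cc1` gives 10.7 nM in a functional assay on cells for positive allosteric modulation of metabotropic glutamate receptor 5 (Rattus norvegicus), read by calcium flux (a higher number here means that more compound is needed for the effect, a lower number that less compound is needed), the lowest of the two numbers so far; its only neighbour, compound 1 `Cc1ccc(C(=O)Nc2cc(-c3ccccc3)nn2-c2ccccc2)cc1`, gives 64 nM. Among the measured compounds shown here, the single measured step, a 6.0-fold lower number from compound 1 to compound 2 (0.78 log units; beyond the scatter), concerns a change on the aromatic ring of the amide, not its replacement. Compound 3 `O=C(Nc1cc(-c2ccccc2)nn1-c1ccccc1)C1CCCC1` differs from compound 2 in cyclopentyl in place of 4-nitrophenyl on a carbonyl carbon. For the measured compounds named here, no measured step covers the exchange of an aromatic ring for a saturated one, so the known step bears on this only loosely. Because the gain seen in a 6.0-fold lower number from compound 1 to compound 2 (0.78 log units; beyond the scatter) sat on a group that is now removed, a rise beyond the scatter is expected, with wide uncertainty. For compound 3 the expected value is 300 nM, with a likely range from 50 nM to 3000 nM. The step of a 28-fold higher number from compound 2 to compound 3 (1.45 log units; beyond the scatter) is thus what is expected.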

Compound 3, half-maximal effective concentration: 3410 nM
For compound 3 the middle estimate is 11-fold (1.06 log units) below the measured one, outside the stated range (above it).
By their numbers in this assay, from the lowest: compound 2; then compound 1; then compound 3.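

In this assay, among these compounds, the earlier compounds changed only a group carried on the aromatic ring, whereas this change replaces the ring itself, and the effect is much larger. Cyclopentyl in place of 4-nitrophenyl on the carbonyl carbon gives a 320-fold higher number from compound 2 to compound 3 (2.50 log units; beyond the scatter), and cyclopentyl in place of 4-methylphenyl gives a 53-fold higher number from compound 1 to compound 3 (1.73 log units; beyond the scatter), so far more compound is needed whichever of the two aromatic groups is replaced. Nothing available explains why this exchange costs so much.

The compounds shown leave open whether the rise comes from losing the aromatic ring or from losing the group on it, a question that an unsubstituted phenyl on the carbonyl carbon could help to settle. They also leave open how other saturated rings, such as cyclohexyl, or an aromatic ring containing nitrogen, such as pyridyl, would behave here.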